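Coumarin-piperazine series: pyridin-2-yl in place of 2-methoxyphenyl

This account rests on a few compounds, and the source may have more. Where it says the series, first, only, none or still open, it means among the compounds named here.

Measured compounds in an assay on thoracic aorta for binding affinity to Alpha-1A adrenergic receptor (Rattus norvegicus); on this read-out lower numbers stand for tighter binding and higher numbers for weaker binding:
compound 1 `COc1cc(=O)oc2cc(OCCCN3CCN(c4ccccc4)CC3)ccc12`, 355 nM
compound 2 `COc1ccccc1N1CCN(CCCOc2ccc3c(C)cc(=O)oc3c2)CC1`, 0.851 nM
compound 3 `COc1ccccc1N1CCN(CCCOc2ccc3c(OC)cc(=O)oc3c2)CC1`, 7.94 nM

Compound 3 stands second highest of the three numbers in this assay: a 9.3-fold higher number from compound 2 to compound 3 (0.97 log units; beyond the scatter), and a 45-fold lower number from compound 1 to compound 3 (1.65 log units; beyond the scatter). Compound 4 `COc1cc(=O)oc2cc(OCCCN3CCN(c4ccccn4)CC3)ccc12` differs from compound 3 by pyridin-2-yl in place of 2-methoxyphenyl on an amine nitrogen in a ring. For the measured compounds named here, no measured step changes the group on the ring nitrogen, so none bears directly on this change. Compounds 1 and 2 only show that the series spans a wide range of numbers, so a step in either direction beyond the scatter is plausible. Compound 4 is expected to give a higher number, with a 13-fold higher number from compound 3 to compound 4 (1.10 log units; beyond the scatter) estimated. The estimate for compound 4 is 100 nM, in the range 20 nM to 600 nM.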

Compound 4, dissociation constant: 191 nM
Compound 4: the middle estimate sits 1.9-fold (0.28 log units) below what was measured, within the range that was stated.
By their numbers in this assay, from the lowest: compound 2; then compound 3; then compounds 4 and 1 (each within the scatter of the next).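

In this assay, for the compounds shown here, this is the first read of a change to the group on the ring nitrogen: pyridin-2-yl in place of 2-methoxyphenyl gives a large loss of binding (a 24-fold higher number from compound 3 to compound 4 (1.38 log units; beyond the scatter)). Pyridin-2-yl in place of phenyl gives no change that can be read (a 1.9-fold lower number from compound 1 to compound 4 (0.27 log units; within the scatter)), so the two groups are not told apart at this position. No evidence on hand bears on the cause of either step.

Open, as far as these compounds go, is how 2-ethoxyphenyl or pyrimidin-2-yl on the ring nitrogen would compare. Also open, from the compounds shown here alone, is whether the 2-methoxyphenyl to pyridin-2-yl step carries over to the core of compound 2.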